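The compounds below may be only part of what the source reports. "The series", "measured", "known", "first", "only" and "open" are said of these compounds alone.

Measured so far in a functional assay on CCRF-CEM cells (Homo sapiens) for antiproliferative activity, read by MTT assay, with a stated time of 72 h, tested at 100 uM; on this read-out lower numbers stand for a stronger effect and higher numbers for a weaker effect at the one concentration tested:
- compound 1 `COC(C(=O)OC(C)Cn1cnc2c1c(=O)n(C)c(=O)n2C)c1cccc2ccccc12`: 51.4%
- compound 2 `CC(Cn1cnc2c1c(=O)n(C)c(=O)n2C)OC(=O)CC(=O)c1ccc(F)cc1`: 43.8%

For the measured compounds named here, only two compounds have been measured, and no step between compounds differing in one place exists among them. Compound 1 and compound 2 give numbers that lie within the usual scatter of each other, so on the numbers shown compound 1 cannot be set apart from compound 2, and no order between them is claimed.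

Compound 3 `COC(C(=O)OC(C)Cn1cnc2c1c(=O)n(C)c(=O)n2C)c1ccc2ccccc2c1` is the unmeasured member of the series. It differs from compound 1 in one place: naphthalen-2-yl in place of naphthalen-1-yl on a saturated chain carbon bound to a carbonyl carbon and an oxygen on a saturated carbon. The two groups have the same atoms, joined differently, and nothing is added or removed.

Going by the values given here, no measured pair informs this kind of change in this assay. The expectation is a step of no size beyond the scatter, in either direction, and the expected step is a number 1.4 percentage points lower from compound 1 to compound 3 (within the scatter). On that basis compound 3 is estimated to give about 50% in this assay, within 35% to 65%.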

Compound 3, a percentage reported as activity, at one concentration (the size of the read-out at that concentration, not a potency): 27.6%
Compound 3: middle estimate off by 22.4 percentage points, on the high side, outside the stated range (below it).
By their numbers in this assay, from the lowest: compound 3; then compounds 2 and 1 (each within the scatter of the next).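

The position on a saturated chain carbon bound to a carbonyl carbon and an oxygen on a saturated carbon responds to how the aromatic group is joined, and not only to which atoms it holds: in this assay, naphthalen-2-yl in place of naphthalen-1-yl comes with a number 23.8 percentage points lower from compound 1 to compound 3 (beyond the scatter) at the one concentration tested. The two groups have the same counts of heavy atoms, rings, donors and acceptors, so these counts do not separate the two compounds. Nothing measured here gives a reason for the step.

One pair cannot show whether this preference for naphthalen-2-yl carries over to other groups at this position, such as phenyl or quinolin-2-yl. As far as these compounds go, the role of the methoxy on the same carbon also stays open, and a hydroxyl or an amine there would test it.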